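The source may report more compounds than this note shows. Statements on the series, on what has been measured and on what is new or still open speak of the compounds shown alone.

Compound 1 `CCCOC(=O)OCC(CO)CCn1cnc2cnc(N)nc21`. In a functional assay on Vero cells (Chlorocebus sabaeus) for cytotoxicity (on this read-out higher numbers stand for lower toxicity in this test and lower numbers for higher toxicity in this test), compound 1 gives > 500000 nM, which is a limit of the assay and not a number.
Compound 2 `CCCCCOC(=O)OCC(CO)CCn1cnc2cnc(N)nc21`. In this assay compound 2 gives > 500000 nM, again a limit of the assay.
Compound 3 `CCCCOC(=O)OCC(CO)CCn1cnc2cnc(N)nc21`. In this assay compound 3 gives > 500000 nM, also a limit of the assay.

The step that the two limits leave unreadable from compound 2 to compound 1 goes with the change (hydrogen in place of ethyl on a saturated chain carbon, three bonds along the chain from an oxygen next to a carbonyl group). The same kind of change is made from compound 3 to compound 4 `CCOC(=O)OCC(CO)CCn1cnc2cnc(N)nc21`, as hydrogen in place of ethyl on a saturated chain carbon, two bonds along the chain from an oxygen next to a carbonyl group; here the place differs, lying two bonds along the chain from an oxygen next to a carbonyl group rather than three. The cores of compound 3 and compound 2 differ by hydrogen in place of methyl on a saturated chain carbon, four bonds along the chain from an oxygen next to a carbonyl group. For the measured compounds named here, every value so far sits at the limit of > 500000 nM in this assay, at which 3 of the 3 values shown sit, so no step size can be read. The step that the limit leaves unreadable from compound 3 to compound 4 is expected, resting on the limit of compound 3 in this assay of > 500000 nM. Compound 4 is therefore estimated at 700000 nM, most likely reported once more as a limit.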

Compound 4, half-maximal cytotoxic concentration: > 500000 nM
Compound 4 was reported as a limit; the forecaster's own chance of this, stated with the estimate: 85%; the middle value lies beyond the limit too.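

In this assay, for the compounds shown here, compound 4 also gives a limit, so no step among compound 1, compound 2, compound 3 and compound 4 can be read: the limit of > 500000 nM in this assay, at which 4 of the 4 values shown sit. The compounds shown leave open whether the length of the chain matters for cytotoxicity at all.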